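A few compounds are considered here, and "the series" means these few. Any claim that something is new, unique, unknown or untested is made for them only; others in the source may bear on it.

Compounds measured:
Compound 1, `CC(=O)c1ccc(C(=O)N[C@@H](C)Cn2ccc(-c3ccc(C#N)c(Cl)c3)n2)cc1`: 3600 nM
Compound 2, `CC(=O)c1cccc(NC(=O)C(C)Cn2ccc(-c3ccc(C#N)c(Cl)c3)n2)c1`: 1540 nM
Compound 3, `C[C@@H](Cn1ccc(-c2ccc(C#N)c(Cl)c2)n1)NS(=O)(=O)c1cccnc1`: 6140 nM

All three were tested in a functional assay on LNCaP cells (Homo sapiens) for antiproliferative activity, read by CCK-8 assay, with a stated time of 6 days; a lower number here means a stronger inhibitor, a higher number a weaker inhibitor. Compound 3 gives the highest of the three numbers. Against compound 1 its value lies within the usual scatter, so no order between the two can be drawn. Against compound 2 the gap is beyond the scatter, and compound 2 shows the lower number.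

Compound 4, `Cc1ccnc(N[C@@H](C)Cn2ccc(-c3ccc(C#N)c(Cl)c3)n2)n1`, has not been measured. It differs from compound 3 in one place: 4-methylpyrimidin-2-yl in place of (pyridin-3-yl)sulfonyl on an amine nitrogen. For the measured compounds named here, no pair of measured compounds shows a step of this kind, so the size of the step in this assay cannot be read from the data. Compound 3 stands at the high end of the set, and the group that enters is smaller and carries fewer acceptors than the one that leaves; a moderate move toward a lower number is expected, though it could still fall within the scatter. Compound 4 is expected to give about 2500 nM, in a range from 600 nM to 10000 nM, which means an expected step of a 2.5-fold lower number from compound 3 to compound 4 (0.39 log units; beyond the scatter).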

Compound 4, half-maximal inhibitory concentration: 1330 nM
Compound 4: the middle estimate sits 1.9-fold (0.27 log units) above what was measured; the measured number falls inside the stated range.
By their numbers in this assay, from the lowest: compounds 4 and 2 (each within the scatter of the next); then compounds 1 and 3 (each within the scatter of the next).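

In this assay, the group on the amine nitrogen of the shared core proves able to move the number on its own: 4-methylpyrimidin-2-yl in place of (pyridin-3-yl)sulfonyl gives a 4.6-fold lower number from compound 3 to compound 4 (0.66 log units; beyond the scatter), a step beyond the usual scatter. The earlier compounds shown here could not show this, since none of them differed from another in only one place. Nothing given here bears on why the step has this size.

From the compounds shown here alone, the change swaps the sulfonyl link and the ring at once, so what each part contributes remains open, and a phenyl group attached directly to the same nitrogen would separate the two. Going by these compounds, the part played by the methyl also remains open, and pyrimidin-2-yl without it, or with a methoxy group instead, would test that.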